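Swapping the ring on the amine nitrogen for a carbamate

A few compounds are considered here, and "the series" means these few. Any claim that something is new, unique, unknown or untested is made for them only; others in the source may bear on it.

Measured so far:
compound 1 `CCS(=O)(=O)c1ccc(COC[C@@H]2C[C@@H]2C2CCN(c3nc(C(C)C)no3)CC2)c(F)c1` with 0.8 nM
compound 2 `CC(C)c1noc(N2CCC([C@H]3C[C@H]3COCc3ccc(-n4cnnn4)cc3F)CC2)n1` with 1.7 nM

These two compounds share one core and differ at a single place on the aromatic ring. In a functional assay on CHO cells for agonist activity at Glucose-dependent insulinotropic receptor (Homo sapiens), read by cAMP accumulation (a higher number here means that more compound is needed for the effect, a lower number that less compound is needed), compound 1 gives 0.8 nM. Compound 2 gives 1.7 nM in this assay, which is the higher of the two numbers; the step of a 2.1-fold higher number from compound 1 to compound 2 (0.33 log units; beyond the scatter) is a modest one.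

Compound 3 `CC1(OC(=O)N2CCC([C@H]3C[C@H]3COCc3ccc(-n4cnnn4)cc3F)CC2)CC1` has not yet been measured. It differs from compound 2 at another place entirely: ((1-methylcyclopropyl)oxy)carbonyl in place of 3-isopropyl-1,2,4-oxadiazol-5-yl on an amine nitrogen in a ring. Going by the values given here, no measured step touches this position; the only step on record, a 2.1-fold higher number from compound 1 to compound 2 (0.33 log units; beyond the scatter), concerns the aromatic ring and says nothing about what happens at the amine nitrogen. Among the compounds with values here, the expectation for compound 3 therefore rests on little more than the size of the one change seen so far, which was modest.

The step from compound 2 to compound 3 is expected to be a 1.8-fold higher number from compound 2 to compound 3 (0.25 log units; within the scatter), a small worsening that may not exceed the scatter. Compound 3 is accordingly estimated at 3 nM, within a range from 0.8 nM to 12 nM.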

Compound 3, half-maximal effective concentration in the Glucose-dependent insulinotropic receptor assay: 4.8 nM
Beside the measured number, compound 3's estimate is 1.6-fold (0.20 log units) below it, within the range that was stated.
By their numbers in the Glucose-dependent insulinotropic receptor assay, from the lowest: compound 1; then compound 2; then compound 3.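

Placing ((1-methylcyclopropyl)oxy)carbonyl on the amine nitrogen in place of 3-isopropyl-1,2,4-oxadiazol-5-yl gives, in the Glucose-dependent insulinotropic receptor assay, a 2.8-fold higher number from compound 2 to compound 3 (0.45 log units; beyond the scatter), the first evidence that this position affects the result, and a step larger than the scatter, with compound 2 at 1.7 nM and compound 3 at 4.8 nM. Going by these compounds alone, the five-membered aromatic ring is therefore not essential, since compound 3, with a carbamate and a three-membered carbon ring in its place, still gives 4.8 nM in the same assay, although that number is higher than the one for compound 2. In a physicochemical assay for lipophilicity, read by HPLC, at pH 7 (on this read-out higher numbers stand for higher lipophilicity and lower numbers for lower lipophilicity), the same swap gives a number 0.10 log units lower from compound 2 to compound 3 (within the scatter), with compound 2 at 3.9 and compound 3 at 3.8, so the two compounds cannot be told apart on this read-out, and no measured evidence here accounts for the step in receptor activity.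

Compound 3 alters the link to the ring nitrogen and the group at the end of it together, so the compounds shown cannot assign the step to either part, and a tert-butyl carbamate or a pyrimidine ring on that nitrogen would help separate them. As far as these compounds go, it also remains open whether the carbamate would produce a similar step with ethylsulfonyl on the aromatic ring, as in compound 1.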